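The compounds below may be only part of what the source reports. "The series", "measured", "known", "first", "only" and "open" are said of these compounds alone.

Working notes on the series. The shared core of compound 1 `CC(C)(C)OC(=O)Nc1ncc(C(Oc2ccc(Br)cc2)c2ccc(Cl)cc2)s1` carries a carbamate on the aromatic nitrogen. In an ADME assay on HepG2 2.2.15 cells (Homo sapiens) for cytotoxicity (a higher number here means that more compound is tolerated, a lower number that less compound is tolerated), compound 1 gives only a limit of the assay, > 50000 nM. Compound 2 `CC(C)(C)OC(=O)Nc1ncc(C(Oc2ccc(F)c(Cl)c2)c2ccc(Cl)cc2)s1` carries the same core. In this assay compound 2 likewise gives only a limit of the assay, > 50000 nM. The step from compound 1 to compound 2 in this assay reads a step that the two limits leave unreadable from compound 1 to compound 2; the two limits leave its size unreadable, a point noted as the limit of > 50000 nM in this assay, at which 2 of the 3 values shown sit.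

Compound 3 `CCCCC(CC)CNc1ncc(C(Oc2ccc3cc(Br)ccc3c2)c2ccc(Cl)cc2)s1` replaces the carbamate with an alkylamine. In this assay compound 3 is recorded only as "not toxic" (no number reported), without a number, so no single value places it among the others.

Compound 4 `COCCCNc1ncc(C(Oc2ccc3cc(Br)ccc3c2)c2ccc(Cl)cc2)s1` differs from compound 3 by a single change: 2-methoxyethyl in place of 1-ethylpentyl on a saturated chain carbon bound to a nitrogen on an aromatic ring.

Among the measured compounds shown here, none of the measured steps covers this change; the only measured step, between compound 1 and compound 2, touches the aryl ether and is itself unreadable. Every value shown so far sits at or beyond the upper end of this assay, and no step beyond the scatter has been observed in this series. On that basis compound 4 is expected to behave like compound 3, with an estimated value of 50000 nM in this assay, in the range 20000 nM to 100000 nM, most probably again reported only as a limit.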

Compound 4, half-maximal cytotoxic concentration: "not toxic" (no number reported)
Compound 4: no number reported; there is nothing to compare the estimate with.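

Compound 3 and compound 4 are both recorded as not toxic without a number in this assay; no new step can be read between them. The compounds shown leave open whether any single change, on the amine chain or the aryl ether, moves the tolerated concentration, with no exact value on record: the limit of > 50000 nM in this assay, at which 2 of the 4 values shown sit.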